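Working notes on compound 4 from compound 2

The source may hold more compounds than are shown below. What is called first, only, known or untested is meant among the compounds shown, and "the series" means these compounds.

Compound 1 `Cc1ccc(N2CCN(C(=O)Nc3ccc(C(C)C)cc3)CC2)nn1`, compound 2 `Cc1ccc(N2CCN(C(=O)Nc3ccc(OC(F)(F)F)cc3)CC2)nn1` and compound 3 `O=C(Nc1ccc(OC(F)(F)F)cc1)N1CCN(c2ccc(-c3ccccc3)nn2)CC1` share one core and were tested in an assay on HEK293 cells for inhibition of transient receptor potential cation channel subfamily V member 1 (Homo sapiens), read by FLIPR, at pH 5.5; a lower number here means a stronger inhibitor, a higher number a weaker inhibitor. Compound 1 gives > 10000 nM, which is a limit of the assay and not a number. Compound 2 likewise gives only the limit > 10000 nM. Compound 3 also stops at the limit > 10000 nM. Compound 2 thus stands at a limit, as do the two other values, which is the limit of > 10000 nM in this assay, at which 3 of the 3 values shown sit. The steps a step that the two limits leave unreadable from compound 1 to compound 2 and a step that the two limits leave unreadable from compound 2 to compound 3 are unreadable, as the limit of > 10000 nM in this assay, at which 3 of the 3 values shown sit, shows. Compound 4 `O=C(Nc1ccc(OC(F)(F)F)cc1)N1CCN(c2nncc3ccccc23)CC1` differs from compound 2 by a group of 10 heavy atoms (8 carbon, 2 nitrogen; one six-membered aromatic ring of carbon only, one six-membered aromatic ring with 2 hetero atoms) in place of a group of 7 heavy atoms (5 carbon, 2 nitrogen; one six-membered aromatic ring with 2 hetero atoms), on an amine nitrogen in a ring. Within the data shown here, no measured step reads on this change, so no direction in this assay can be drawn. Compound 4 is expected near 20000 nM, within 4000 nM to 100000 nM, probably again reported as a limit. The step that the limit leaves unreadable from compound 2 to compound 4 is expected to stay within the scatter.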

Compound 4, half-maximal inhibitory concentration: > 10000 nM
Compound 4 gave a limit, no number (the forecaster's own chance of this, stated with the estimate: 75%); the middle value is on the limit's open side.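

Compound 4, like compound 2, stops at a limit, so no new step can be read from this pair: the limit of > 10000 nM in this assay, at which 4 of the 4 values shown sit. In this assay the compounds shown leave open which change to the shared core, if any, would give a readable number.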